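A few compounds are considered here, and "the series" means these few. Any claim that something is new, unique, unknown or untested is made for them only; others in the source may bear on it.

Measured so far in a functional assay on HCT-116 cells (Homo sapiens) for cytotoxicity, read by MTT assay, with a stated time of 48 h; a lower number here means a stronger inhibitor, a higher number a weaker inhibitor:
compound 1 `Cc1nc2c3ccccc3ccc2c2nc3c(ccc4ccccc43)c(-c3cc([N+](=O)[O-])ccc3N)c12` gives 6010 nM.
compound 2 `Cc1nc2c3ccccc3ccc2c2nc3c(ccc4ccccc43)c(C)c12` gives only a limit, > 80000 nM.

Compound 2 thus stands at the limit of this assay (the limit of > 80000 nM in this assay, at which 1 of the 2 values shown sits), not at a number. Compound 3 `Cc1nc2c3ccccc3ccc2c2nc3c(ccc4ccccc43)c(-c3ccccc3)c12` differs from compound 2 by phenyl in place of methyl on an aromatic carbon. Within the data shown here, the single measured step bearing on this position is an at least 13-fold higher number from compound 1 to compound 2 (1.12 log units; beyond the scatter), large and beyond the scatter. Phenyl brings back an aromatic ring at this carbon but carries neither the amino nor the nitro group of compound 1. A lower number than at compound 2 is expected, with a step short of that measured one. Compound 3 is estimated at 30000 nM (range 8000 nM to 80000 nM), an expected step of an at least 2.6-fold lower number from compound 2 to compound 3 (0.42 log units; beyond the scatter).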

Compound 3, half-maximal inhibitory concentration: > 80000 nM
Compound 3 gave a limit, no number (the forecaster's own chance of this, stated with the estimate: 35%); middle value at least 2.6-fold (0.42 log units) from the limit.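

In this assay compound 3 gives > 80000 nM, a limit and not a number. Phenyl in place of 2-amino-5-nitrophenyl gives an at least 13-fold higher number from compound 1 to compound 3 (1.12 log units; beyond the scatter), so an unsubstituted aromatic ring at this carbon does not retain the value of compound 1. The step between compound 2 and compound 3 cannot be read, and the two share one limit: the limit of > 80000 nM in this assay, at which 2 of the 3 values shown sit.

Open, on these data alone, is whether the amino group, the nitro group or the two together account for the measurable value of compound 1. A phenyl carrying only the amino group or only the nitro group would separate these cases.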